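Aryl Ether Swap and Human Liver Microsome Clearance

The source may hold more compounds than are shown below. What is called first, only, known or untested is meant among the compounds shown, and "the series" means these compounds.

Measured compounds:
compound 1 `CC(C)COc1ncc(-c2cc(F)c(-c3nnc(S(C)(=O)=O)[nH]3)cc2F)cc1Cl`: 41 uL/min
compound 2 `Cc1ccc(Cl)c(Oc2ncc(-c3cc(F)c(-c4nnc(S(=O)(=O)CC5CC5)[nH]4)cc3F)cc2Cl)c1`: 41 uL/min

In an ADME assay on microsomes from liver (Homo sapiens) for metabolic stability (a higher number here means faster removal of the compound, a lower number slower removal), compound 1 gives 41 uL/min, and in the same assay compound 2 gives 41 uL/min. Compound 2 stands level with compound 1 at the digits shown; the two values lie within the usual scatter of this assay, so no order can be read between them. For the measured compounds named here, no step between measured compounds that differ in a single place is available.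

Compound 3 `O=S(=O)(CC1CC1)c1nnc(-c2cc(F)c(-c3cnc(Oc4ccc(F)cc4Cl)c(Cl)c3)cc2F)[nH]1` differs from compound 2 in one place: 2-chloro-4-fluorophenyl in place of 2-chloro-5-methylphenyl on an oxygen on an aromatic ring. Going by the values given here, nothing among the measured compounds shows how a change of this kind moves the read-out in this assay; the only comparison available, compound 1 against compound 2, concerns another part of the structure and shows no change beyond the scatter. The step of a 1.1-fold lower number from compound 2 to compound 3 (0.06 log units; within the scatter) is therefore expected to be small, with no direction claimed beyond the scatter. The estimate for compound 3 in this assay is 36 uL/min, with a range from 18 uL/min to 72 uL/min.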

Compound 3, intrinsic clearance in a liver preparation (reported as CLH), per the amount of preparation that the assay uses: < 14 uL/min
Compound 3 gave a limit, no number (the forecaster's own chance of this, stated with the estimate: 5%); middle value at least 2.5-fold (0.41 log units) away from the limit.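

The position on the oxygen matters in this assay: 2-chloro-4-fluorophenyl in place of 2-chloro-5-methylphenyl brings an at least 2.9-fold lower number from compound 2 to compound 3 (0.46 log units; beyond the scatter), and this is the only step among the compounds shown, so it gives the first reading of how a change at this position moves the read-out. Compound 3 gives < 14 uL/min, which is a limit of the assay and not a number. The step is therefore a minimum, and its full size cannot be read from these data: the limit of < 14 uL/min in this assay, at which 1 of the 3 values shown sits.

The single step removes a methyl and brings in a fluorine at a different place on the ring, so the compounds shown cannot tell which of the two goes with the lower number, and 2-chloro-4-methylphenyl or 2-chloro-5-fluorophenyl on the same oxygen would separate them. As far as these compounds go, it also remains open whether other groups at this position, such as a nitrile or a methoxy on the ring, would give a similar step, and whether the step would hold with a different group on the sulfonyl.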